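Para substituents on the phenyl of the shared core

The source may report more compounds than this note shows. Statements on the series, on what has been measured and on what is new or still open speak of the compounds shown alone.

Measured compounds in a functional assay on T47D cells (Homo sapiens) for cytotoxicity, with a stated time of 72 h, tested at 10 ug/mL; a higher number here means a stronger effect of the compound at the concentration tested, a lower number a weaker effect:
compound 1 `O=c1[nH]nc2n(c1=O)CCN2c1ccccc1`, 0%
compound 2 `Cc1ccc(N2CCn3c2n[nH]c(=O)c3=O)cc1`, 14%
compound 3 `O=c1[nH]nc2n(c1=O)CCN2c1ccc(Cl)cc1`, 5%

Compound 3 carries chloro where compound 1 carries hydrogen and compound 2 carries methyl; all three share the core of compound 1. In this assay the number of compound 3 lies within the scatter of both neighbours: a number 5 percentage points higher from compound 1 to compound 3 (within the scatter) and a number 9 percentage points lower from compound 2 to compound 3 (within the scatter). Among the compounds with values here, only the step of a number 14 percentage points higher from compound 1 to compound 2 (beyond the scatter) reaches beyond the scatter.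

Compound 4 `COc1ccc(N2CCn3c2n[nH]c(=O)c3=O)cc1` differs from compound 3 in one place: methoxy in place of chloro on an aromatic carbon. Within the data shown here, the steps that bear on this change are the two into compound 3 just named, both within the scatter. Among the measured compounds shown here, no step involving methoxy has been measured, so the change is not anchored by any direct precedent. Given that chloro, methyl and hydrogen at this position all return numbers within a narrow band in this assay, no step beyond the scatter is expected: a number 3 percentage points higher from compound 3 to compound 4 (within the scatter). For compound 4 the expected inhibition is 8%, with a range from 0% to 22%.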

Compound 4, a percentage reported as inhibition, at one concentration (the size of the read-out at that concentration, not a potency): 7%
The estimate for compound 4 lay 1 percentage points above the measured number; the measured number falls inside the stated range.
By their numbers in this assay, from the lowest: compounds 1, 3, 4 and 2 (each within the scatter of the next, the first and the last beyond it).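

In this assay, within the data shown here, methoxy, the only one of the four groups at this position counted with a hydrogen-bond acceptor, stays within the scatter of all three others: a number 2 percentage points higher from compound 3 to compound 4 (within the scatter), a number 7 percentage points lower from compound 2 to compound 4 (within the scatter) and a number 7 percentage points higher from compound 1 to compound 4 (within the scatter). Among these compounds, compound 4 therefore does not separate from the unsubstituted compound 1, and the methyl of compound 2 still gives the only step beyond the scatter, a number 14 percentage points higher from compound 1 to compound 2 (beyond the scatter). No measurement bears on why these numbers fall as they do.

From the compounds shown here alone, whether an amine, a carboxylic acid or a longer chain such as butoxy at this position would move the number beyond the scatter of compound 1 remains open. These single-concentration readings also leave open whether the stronger effect of compound 2 than of compound 1 at this concentration would hold at other concentrations.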